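The compounds below may be only part of what the source reports. "The series", "measured", "known", "first", "only" and "open" are said of these compounds alone.

Measured compounds in an assay on isolated protein for inhibition of Rho-associated protein kinase 2 (Homo sapiens), read by HTRF, with a stated time of 4 h; on this read-out higher numbers stand for weaker inhibition and lower numbers for stronger inhibition:
- compound 1 `Cc1cccc(CNC(=O)Nc2ccc(-c3cn[nH]c3)cc2)c1` gives 33 nM; 33 nM (2 entries)
- compound 2 `O=C(NCc1cccc(Cl)c1)Nc1ccc(-c2cn[nH]c2)cc1` gives 17 nM; 17 nM (2 entries)
- compound 3 `COc1cccc(CNC(=O)Nc2ccc(-c3cn[nH]c3)cc2N(C)C)c1` gives < 1 nM

For compound 3 the entry is a limit of the assay, not a number, and two further entries for compound 3 also carry no single number. Of the three values shown, compound 3 therefore sits at the strong end because of the limit of < 1 nM in this assay, at which 1 of the 3 values shown sits. Compound 4 `COc1cccc(CNC(=O)Nc2ccc(-c3cn[nH]c3)cc2Cl)c1` has not yet been tested in this assay. It differs from compound 3 in one place: chloro in place of dimethylamino on an aromatic carbon. Among the measured compounds shown here, no measured pair shows this exchange, so the size of the step is open. The author expects compound 4 to lose some inhibition, with a step of an at least 3.0-fold higher number from compound 3 to compound 4 (0.47 log units; beyond the scatter), while remaining potent. The estimate for compound 4 is 3 nM, within 0.6 nM to 15 nM.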

Compound 4, half-maximal inhibitory concentration: < 1 nM
Compound 4 ended at the assay's limit; the forecaster's own chance of this, stated with the estimate: 25%; at least 3.0-fold (0.47 log units) between middle value and limit.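

Compound 3 and compound 4 both end at a limit of the assay rather than at a number, so no step between them can be read: the limit of < 1 nM in this assay, at which 2 of the 4 values shown sit.

From the compounds shown here alone, whether chloro and dimethylamino differ at all in this assay remains open.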